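The source may report more compounds than this note shows. Statements on the series, on what has been measured and on what is new or still open speak of the compounds shown alone.

Measured so far:
compound 1, `O=C1C=COC(/C=C/c2ccccc2)C1`: 58.2 uM
compound 2, `COc1ccc(/C=C/C2CC(=O)C=CO2)cc1OC`: 74.3 uM
compound 3, `O=c1ccoc(/C=C/c2ccccc2)c1`: 546 uM

All three were run in a functional assay on OVCAR-3 cells (Homo sapiens) for inhibition, read by sulforhodamine B assay, with a stated time of 48 h; on this read-out higher numbers stand for weaker inhibition of growth and lower numbers for stronger inhibition of growth. Compound 3 stands at the highest of the three numbers and is the weakest inhibitor of growth among them; its gap to compound 2 and its gap to compound 1 both lie beyond the usual scatter, compound 2 being the nearer. Among the measured compounds shown here, compounds 1 and 2 differ in more than one place, so no step is drawn between them; their two numbers lie within the scatter of each other.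

Compound 4, `COc1ccc(/C=C/c2cc(=O)cco2)cc1`, is not yet measured. It differs from compound 3 in one place: methoxy in place of hydrogen on an aromatic carbon The site is on an aromatic carbon of a six-membered aromatic ring of carbon only, para to a group of 9 heavy atoms. For the measured compounds named here, no measured pair isolates this change. Given that compound 1 at 58.2 uM and compound 2 at 74.3 uM sit together, no step beyond the scatter is expected in this assay, in either direction. Compound 4 is therefore expected to give about 450 uM, within 150 uM to 1200 uM. The implied step a 1.2-fold lower number from compound 3 to compound 4 (0.08 log units; within the scatter) is estimated to be small.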

Compound 4, concentration for growth inhibition (reported as GI): 328 uM
Compound 4: middle estimate off by 1.4-fold (0.14 log units), on the high side; measured number inside the range.
By their numbers in this assay, from the lowest: compounds 1 and 2 (each within the scatter of the next); then compounds 4 and 3 (each within the scatter of the next).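

In this assay, among the compounds shown here, methoxy in place of hydrogen on an aromatic carbon, para to a group of 9 heavy atoms, gives a first isolated reading of this change (a 1.7-fold lower number from compound 3 to compound 4 (0.22 log units; within the scatter)). On the core of compound 3, this position therefore accepts methoxy with no step beyond the scatter in either direction. Nothing at hand accounts for the size of this step.

On these data alone, whether a different group at the same place, such as an amine or a carboxylic acid, would give a step beyond the scatter remains open. Also open is whether methoxy behaves the same way on the core of compound 1, since no pair among the compounds shown isolates this change on that core.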